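From a Methyl Thiadiazole to a Pyridyl Thiazole

The source may report more compounds than this note shows. Statements on the series, on what has been measured and on what is new or still open speak of the compounds shown alone.

In a functional assay on MGC-803 cells (Homo sapiens) for inhibition, read by MTT assay, with a stated time of 72 h (a lower number here means a stronger inhibitor, a higher number a weaker inhibitor), compound 1 (`Cc1csc(Sc2cc(C(F)(F)F)nc(SCc3ccc(C(F)(F)F)cc3)n2)n1`) gives 21300 nM and compound 2 (`Cc1nnc(Sc2cc(C(F)(F)F)nc(SCc3ccc(C(F)(F)F)cc3)n2)s1`) gives 11400 nM. For the measured compounds named here, these are the only two measurements so far, and they lie within the usual scatter of each other, so compound 2 cannot be separated from compound 1 on these numbers.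

The next structure is compound 3 (`FC(F)(F)c1ccc(CSc2nc(Sc3ncc(-c4ccncc4)s3)cc(C(F)(F)F)n2)cc1`), which keeps the rest of compound 2 and changes one group on a sulfur: 5-(pyridin-4-yl)-1,3-thiazol-2-yl in place of 5-methyl-1,3,4-thiadiazol-2-yl on a sulfur. In short, 5-(pyridin-4-yl)-1,3-thiazol-2-yl takes the place of 5-methyl-1,3,4-thiadiazol-2-yl.

Going by the values given here, only one measured step bears on this change. That step, a 1.9-fold lower number from compound 1 to compound 2 (0.27 log units; within the scatter), altered the group on the same sulfur and stayed within the scatter. It offers only a loose guide, since neither compound 1 nor compound 2 carries the added six-membered ring, and the data give no direction for its effect. No shift beyond the scatter is therefore expected in this assay, and the expected step is a 1.3-fold lower number from compound 2 to compound 3 (0.10 log units; within the scatter). For compound 3, the estimated value is 9000 nM, with an expected range of 3000 nM to 30000 nM.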

Compound 3, half-maximal inhibitory concentration: 5770 nM
Beside the measured number, compound 3's estimate is 1.6-fold (0.19 log units) above it; low and high end bracket the measured number.
By their numbers in this assay, from the lowest: compounds 3, 2 and 1 (each within the scatter of the next, the first and the last beyond it).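

The step of a 2.0-fold lower number from compound 2 to compound 3 (0.30 log units; within the scatter) shows that, in this assay, the sulfur of the shared core can carry 5-(pyridin-4-yl)-1,3-thiazol-2-yl, a group with two aromatic rings, in place of the single ring of 5-methyl-1,3,4-thiadiazol-2-yl, with no change that can be separated from the scatter. The comparison with the methyl thiazole gives a 3.7-fold lower number from compound 1 to compound 3 (0.57 log units; beyond the scatter), a modest step, but the first in this short series to pass beyond the scatter, so the group on this sulfur can move the number in this assay. Nothing measured here explains either step.

The compounds shown cannot say whether the pyridine ring itself matters or whether any added six-membered aromatic ring would do the same, a question that a plain phenyl ring on the same thiazole would address. They also leave open how this position would respond to a group of another kind, such as a carboxylic acid or an amine on a longer chain.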